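The compounds below may be only part of what the source reports. "The series", "measured", "known", "first", "only" and "open" are said of these compounds alone.

Compound 1: `CCCCNc1nc(N)nc2c1CN(Cc1ccccc1)CC2`, in an assay on HEK293 cells for agonist activity at Toll-like receptor 8 (Homo sapiens), read by a luciferase reporter, with a stated time of 6 h (on this read-out higher numbers stand for an effect only at larger amounts of compound and lower numbers for an effect already at smaller amounts), compound 1 gives 0.06 uM.
Compound 2: `CCCCNc1nc(N)nc2c1CN(S(C)(=O)=O)CC2`, in this assay compound 2 gives 9.9 uM.
Compound 3: `CCCCNc1nc(N)nc2c1CN(C(=O)C(C)C)CC2`, in this assay compound 3 gives 1.6 uM.

Compound 3 holds the second highest of the three numbers in this assay. Its neighbours are set by a 6.2-fold lower number from compound 2 to compound 3 (0.79 log units; beyond the scatter) on one side and by a 27-fold higher number from compound 1 to compound 3 (1.43 log units; beyond the scatter) on the other, so the amide sits between the methylsulfonyl and the benzyl compounds, far nearer the former than the latter.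

Compound 4, `CCCCNc1nc(N)nc2c1CN(C(=O)c1cscn1)CC2`, has not yet been measured in this assay. Its difference from compound 3 is 1,3-thiazol-4-yl in place of isopropyl on a carbonyl carbon.

Within the data shown here, no measured step swaps the substituent on a carbonyl carbon; all three measured steps exchange the whole group on the ring nitrogen. The most telling is a 27-fold higher number from compound 1 to compound 3 (1.43 log units; beyond the scatter), where the compound carrying an aromatic ring on that nitrogen gives a much lower number than the isopropylcarbonyl compound, and a 6.2-fold lower number from compound 2 to compound 3 (0.79 log units; beyond the scatter) shows the amide already moved modestly by its partner group. Because of a 27-fold higher number from compound 1 to compound 3 (1.43 log units; beyond the scatter), a modest move to a lower number beyond the scatter is expected for compound 4, without reaching compound 1.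

For compound 4 in this assay the estimate is 0.5 uM, with a range from 0.1 uM to 2.5 uM. This estimate means the expected step is a 3.2-fold lower number from compound 3 to compound 4 (0.51 log units; beyond the scatter).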

Compound 4, minimum effective concentration: 0.5 uM
Beside the measured number, compound 4's estimate shows no gap at the digits printed; the range from low to high includes it.
By their numbers in this assay, from the lowest: compound 1; then compound 4; then compound 3; then compound 2.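

Among these compounds, compound 4 gives the only measured change on the carbonyl carbon itself, with the amide-type nitrogen in the ring kept: in this assay the step of a 3.2-fold lower number from compound 3 to compound 4 (0.51 log units; beyond the scatter) shows that the substituent on that carbon can move the number on its own, here with 1,3-thiazol-4-yl in place of isopropyl. The thiazole amide also stands well clear of the methylsulfonyl compound, at a 20-fold lower number from compound 2 to compound 4 (1.30 log units; beyond the scatter), a wider gap than the isopropylcarbonyl compound showed, yet it does not close the distance to the benzyl compound, with an 8.3-fold higher number from compound 1 to compound 4 (0.92 log units; beyond the scatter) still remaining. Nothing measured here accounts for these differences, so they stand only as differences in the numbers.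

The compounds shown leave open whether the lower number follows from having any aromatic ring on the carbonyl carbon or from the nitrogen and sulfur of this particular ring, which a phenyl or a cyclohexyl group in the same place would help to separate. They also leave open whether a 1,3-thiazol-2-yl group would behave like the 1,3-thiazol-4-yl group, and whether a benzoyl group on the ring nitrogen would come closer to the benzyl compound.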